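A few compounds are considered here, and "the series" means these few. Any claim that something is new, unique, unknown or untested is made for them only; others in the source may bear on it.

Working notes on the series. In a functional assay on BXPC-3 cells (Homo sapiens) for cytotoxicity, read by MTT assay, with a stated time of 72 h (a lower number here means a stronger inhibitor, a higher number a weaker inhibitor), compound 1 (`O=C1C(Nc2ccc(OC(F)(F)F)cc2)=CC(=O)c2ncncc21`) gives 900 nM, compound 2 (`Nc1ccc(-c2ccc(NC3=CC(=O)c4ncncc4C3=O)cc2)cc1`) gives 3500 nM and compound 3 (`COc1ccc(-c2ccc(NC3=CC(=O)c4ncncc4C3=O)cc2)cc1`) gives 3500 nM. Compound 3 therefore stands level with compound 2, the pair holding the highest of the three numbers, and compound 1 holds the lowest.

The next compound, compound 4 (`O=C1C(Nc2ccc(CO)cc2)=CC(=O)c2ncncc21`), has hydroxymethyl in place of 4-methoxyphenyl on an aromatic carbon. Two modest steps bear on this change: a 3.9-fold higher number from compound 1 to compound 3 (0.59 log units; beyond the scatter) and a 3.9-fold higher number from compound 1 to compound 2 (0.59 log units; beyond the scatter), each with a substituted phenyl group in place of trifluoromethoxy. The step of no change at the digits printed from compound 2 to compound 3 (within the scatter) shows no separation between the two substituted phenyl compounds. Among the measured compounds shown here, no measured compound carries hydroxymethyl, so the reverse of the step to compound 3 serves only as a rough guide.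

A modest move to a lower number is expected in this assay, with an estimated 2.3-fold lower number from compound 3 to compound 4 (0.37 log units; beyond the scatter). The estimate for compound 4 is 1500 nM, with an expected range of 500 nM to 4500 nM.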

Compound 4, half-maximal inhibitory concentration: 5700 nM
For compound 4 the middle estimate is 3.8-fold (0.58 log units) below the measured one; the measured number lies above the stated range.
By their numbers in this assay, from the lowest: compound 1; then compounds 2, 3 and 4 (each within the scatter of the next).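

Hydroxymethyl, with no ring, does not separate in this assay from the two substituted phenyl groups at this position: a 1.6-fold higher number from compound 3 to compound 4 (0.21 log units; within the scatter), and a 1.6-fold higher number from compound 2 to compound 4 (0.21 log units; within the scatter). The earlier compounds shown here did not show that the outer carbon ring can be absent without a change beyond the scatter, and trifluoromethoxy alone stands apart among the four, with a 6.3-fold higher number from compound 1 to compound 4 (0.80 log units; beyond the scatter). No measurement among the data offers an explanation for this result.

Going by these compounds, with a single compound holding the lower number, it remains open whether that number is particular to trifluoromethoxy or is shared by other small groups such as trifluoromethyl or chlorine. On these data alone, it also remains open how a carboxylic acid or a longer chain ending in a hydroxyl group would compare with hydroxymethyl at this position.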